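Ethoxy in place of methylsulfonyl: the step to compound 4

The compounds below may be only part of what the source reports. "The series", "measured", "known", "first", "only" and "open" are said of these compounds alone.

Among the measured compounds shown here, the series so far holds three compounds on a shared core. Compound 1 `CC(C)Oc1ccc(CNC(=O)c2ccc(C(C)(C)C)cc2)cc1` gives 170 nM in an assay on HeLa cells with Bile acid receptor (Homo sapiens) as the target, read by a luciferase reporter, with a stated time of 24 h; a higher number here means that more compound is needed for the effect, a lower number that less compound is needed. Compound 2 `CC(C)(C)c1ccc(C(=O)NCc2ccc(-c3nnn[nH]3)cc2)cc1` gives 120 nM in this assay, and compound 3 `CC(C)(C)c1ccc(C(=O)NCc2ccc(S(C)(=O)=O)cc2)cc1` gives 3800 nM in this assay. Compound 3 stands at the highest number of the three: the steps of a 22-fold higher number from compound 1 to compound 3 (1.35 log units; beyond the scatter) and a 32-fold higher number from compound 2 to compound 3 (1.50 log units; beyond the scatter) are both large and beyond the scatter, whereas a 1.4-fold lower number from compound 1 to compound 2 (0.15 log units; within the scatter) lies within it.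

Compound 4 `CCOc1ccc(CNC(=O)c2ccc(C(C)(C)C)cc2)cc1` has not yet been measured. It differs from compound 3 by ethoxy in place of methylsulfonyl on an aromatic carbon. The measured step that bears most directly on this change is a 22-fold higher number from compound 1 to compound 3 (1.35 log units; beyond the scatter), in which methylsulfonyl replaced an alkoxy group and the number rose sharply. Run in reverse, an alkoxy group in place of methylsulfonyl should bring the number down by a comparable amount. For the measured compounds named here, compound 4 carries ethoxy rather than isopropoxy, a group not yet seen, and no measured step separates these two alkoxy groups, so the size of the change is taken from compound 1 alone. The step expected is therefore a 19-fold lower number from compound 3 to compound 4 (1.28 log units; beyond the scatter), a large lowering. Compound 4 is expected to give about 200 nM in this assay, within a range from 80 nM to 600 nM.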

Compound 4, half-maximal effective concentration: 160 nM
Compound 4: the middle estimate sits 1.3-fold (0.10 log units) above what was measured; the measured number falls inside the stated range.
By their numbers in this assay, from the lowest: compounds 2, 4 and 1 (each within the scatter of the next); then compound 3.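

At this position, on an aromatic carbon para to a large group, a second alkoxy group now gives a large step away from methylsulfonyl: a 24-fold lower number from compound 3 to compound 4 (1.38 log units; beyond the scatter) in this assay and so the high number of compound 3 no longer rests on isopropoxy alone as the comparison. The two alkoxy groups are not told apart, with a 1.1-fold lower number from compound 1 to compound 4 (0.03 log units; within the scatter) and thus the methyl that separates isopropoxy from ethoxy makes no readable difference here. Ethoxy and 1H-tetrazol-5-yl are also not told apart, with a 1.3-fold higher number from compound 2 to compound 4 (0.12 log units; within the scatter) and so, of the four groups shown at this position, methylsulfonyl is the only one that stands apart.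

Open, on these data alone, is whether a methoxy group, a longer chain such as butoxy, an amine or a carboxylic acid at this position would stay with the three groups that sit together or go with methylsulfonyl. Nothing available bears on why methylsulfonyl stands apart from the other three groups.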